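The source may report more compounds than this note shows. Statements on the series, on what has been measured and on what is new or still open speak of the compounds shown alone.

Compound 1 `O=C(NCc1ccc(S(=O)(=O)c2ccccc2)cc1)c1cc2ccncc2s1` gives 7 nM in an assay for inhibition of Nicotinamide phosphoribosyltransferase (Homo sapiens), read by mass spectrometry, with stated times of 15 min and 30 min (on this read-out higher numbers stand for weaker inhibition and lower numbers for stronger inhibition), the lowest of the three numbers recorded and beyond the scatter from both of the others. Compound 2 `O=C(NCc1ccc(S(=O)(=O)c2ccccc2)cc1)c1cc2ncccc2s1` gives 400 nM, and compound 3 `O=C(NCc1ccc(S(=O)(=O)c2ccccc2)cc1)c1ccc2nncn2c1` gives 370 nM; the steps of a 57-fold higher number from compound 1 to compound 2 (1.76 log units; beyond the scatter) and a 53-fold higher number from compound 1 to compound 3 (1.72 log units; beyond the scatter) both exchange the group on the carbonyl carbon, and between them a 1.1-fold lower number from compound 2 to compound 3 (0.03 log units; within the scatter). Compound 4 `O=C(NCc1ccc(S(=O)(=O)c2cccc(C(F)(F)F)c2)cc1)c1cc2ccncc2s1` differs from compound 1 elsewhere: trifluoromethyl in place of hydrogen on an aromatic carbon, cut one bond further out, phenyl to 3-(trifluoromethyl)phenyl. Within the data shown here, no measured step touches this part of the shared core, so the data give no direct guide to the size of the change. Compound 4 is therefore expected to stay within the scatter of the known number, a 1.1-fold higher number from compound 1 to compound 4 (0.06 log units; within the scatter). The estimate for compound 4 is 8 nM, with a range from 2.5 nM to 25 nM.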

Compound 4, half-maximal inhibitory concentration: 3 nM
Estimate against measurement, compound 4: 2.7-fold (0.43 log units) above; low and high end bracket the measured number.
By their numbers in this assay, from the lowest: compound 4; then compound 1; then compounds 3 and 2 (each within the scatter of the next).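

Replacing phenyl with 3-(trifluoromethyl)phenyl gives a 2.3-fold lower number from compound 1 to compound 4 (0.37 log units; beyond the scatter), showing that this aromatic carbon tolerates trifluoromethyl with a small gain rather than a loss of inhibition. This step is modest beside a 57-fold higher number from compound 1 to compound 2 (1.76 log units; beyond the scatter), seen when the group on the carbonyl carbon was exchanged. Nothing available explains the gain.

The compounds shown leave open whether a methyl group, a chlorine atom or an amine at this carbon would give the same result. They also leave open how trifluoromethyl would behave on another carbon of this ring.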